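The source may report more compounds than this note shows. Statements on the series, on what has been measured and on what is new or still open speak of the compounds shown alone.

Measured so far:
- compound 1, `CN1CCC[C@H]1[C@@H]1COc2cc(N)ccc2O1`: 3500 nM
- compound 2, `CN1CCC[C@H]1[C@H]1COc2cc(-c3ccccc3)ccc2O1`: 5800 nM

Both numbers come from an assay on membranes from HEK293 cells for displacement of a labelled ligand from Neuronal acetylcholine receptor; alpha3/beta4 (Homo sapiens), with a stated time of 5 min; on this read-out higher numbers stand for weaker inhibition and lower numbers for stronger inhibition. Compound 2 stands highest of the two numbers, but its nearest neighbour is compound 1, and the gap between them lies within the scatter, so the two cannot be told apart on this read-out.

Compound 3, `CN1CCC[C@H]1[C@@H]1COc2cc(-c3ccccc3)ccc2O1`, is the next compound. Its difference from compound 2 is counted as the two compounds have the same atoms and bonds and differ only in configuration as drawn: 1 of 2 stereo elements differ; a stereocentre at a saturated ring carbon is drawn S in compound 2 and R in compound 3. In other words, the two compounds share every atom and bond and part only at one drawn stereocentre on a saturated ring carbon.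

Among the measured compounds shown here, no step between measured compounds is available to calibrate what a change of configuration at this centre does. Compound 1 and compound 2 differ in more than one place. At that centre compound 3 is drawn with the same configuration as compound 1, and compound 1 gives 3500 nM. The expectation is therefore a step of a 1.5-fold lower number from compound 2 to compound 3 (0.16 log units; within the scatter) that stays within the scatter, with no direction that can be called. Compound 3 is estimated at 4000 nM, expected to fall between 1000 nM and 16000 nM.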

Compound 3, inhibition constant: 5400 nM
Estimate against measurement, compound 3: 1.4-fold (0.13 log units) below, and the stated range covers the measured number.
By their numbers in this assay, from the lowest: compounds 1, 3 and 2 (each within the scatter of the next).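

In this assay, the step at the saturated ring carbon is a 1.1-fold lower number from compound 2 to compound 3 (0.03 log units; within the scatter), so with phenyl on the aromatic carbon, inverting this one drawn stereocentre does not separate the two compounds. Among the compounds shown here, this is the first direct reading of that centre, and nothing else in the structures enters into it: the fact that compounds 2 and 3 differ only in the configuration as drawn. The second step, phenyl in place of amino on an aromatic carbon with the configuration at the saturated ring carbon held the same, is a 1.5-fold higher number from compound 1 to compound 3 (0.19 log units; within the scatter), so this exchange does not separate its two compounds either.

The centre has been read only with phenyl in place, so the compounds shown leave open whether its configuration would count with amino on the aromatic carbon. They also leave open where a hydroxyl, a methoxy group or a carboxylic acid on that aromatic carbon would fall, and whether the second stereocentre, drawn the same in all the compounds shown, bears on the number.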